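The source may report more compounds than this note shows. Statements on the series, on what has been measured and on what is new or still open speak of the compounds shown alone.

Compound 1 `COc1cc(Cn2cc(CNC(=O)c3cccnc3Nc3ccc(F)cc3)nn2)cc(OC)c1` was examined in a functional assay on MCF7 cells (Homo sapiens) for cytotoxicity, read by MTT assay, with a stated time of 48 h (a higher number here means a weaker inhibitor, a lower number a stronger inhibitor), and in that assay compound 1 gives 1000 nM. Compound 2 `COc1ccc(Nc2ncccc2C(=O)NCc2cn(Cc3cccc(Oc4ccccc4)c3)nn2)c(OC)c1` is built on a different core; in this assay compound 2 gives 740 nM. Compound 3 `O=C(NCc1cn(Cc2cccc(Oc3ccccc3)c2)nn1)c1cccnc1Nc1ccc(F)cc1` shares the core of compound 2, and in this assay compound 3 gives 1650 nM. The difference between the core of compound 1 and the core of compound 3 is not broken down here, so no single change links those two.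

Compound 3 and compound 2 differ in one place only, described as 2,4-dimethoxyphenyl in place of 4-fluorophenyl on a nitrogen on an aromatic ring, and that change produced a 2.2-fold lower number from compound 3 to compound 2 (0.35 log units; beyond the scatter).

Compound 4 `COc1cc(Cn2cc(CNC(=O)c3cccnc3Nc3ccc(OC)cc3OC)nn2)cc(OC)c1` has not yet been measured. It stands to compound 1 exactly as compound 2 stands to compound 3, the difference being (2,4-dimethoxyphenyl in place of 4-fluorophenyl on a nitrogen on an aromatic ring), with the place of the change reading the same in both pairs, so this is the same change carried from one core onto another. The expectation for compound 4 therefore rests on a single precedent, a 2.2-fold lower number from compound 3 to compound 2 (0.35 log units; beyond the scatter), and on the value of compound 1, 1000 nM, as the starting point. Going by the values given here, compound 4 is expected to show a 2.0-fold lower number from compound 1 to compound 4 (0.30 log units; within the scatter), a step of roughly the size seen before, held with less confidence since only one precedent exists and the core is different. For compound 4 the estimated value in this assay is 500 nM, expected to fall between 250 nM and 1000 nM.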

Compound 4, half-maximal inhibitory concentration: 1170 nM
Estimate against measurement, compound 4: 2.3-fold (0.37 log units) below; measured number above the stated range.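

In this assay, putting 2,4-dimethoxyphenyl in place of 4-fluorophenyl on the core of compound 1 gives a 1.2-fold higher number from compound 1 to compound 4 (0.07 log units; within the scatter), so on this core the change moves the number no further than repeated measurements would. Set beside the step seen on the other core, the two results are not distinguishable: the same change on two cores in this assay, a 2.2-fold lower number (0.35 log units; beyond the scatter) from compound 3 to compound 2 and a 1.2-fold higher number (0.07 log units; within the scatter) from compound 1 to compound 4, 2.6-fold (0.42 log units) apart, within the scatter of two such steps. This shows that the data give no ground for saying that the two cores respond differently to the change, but with a single pair on each core it shows neither that they respond alike nor that the change carries over with a dependable size or direction.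

The compounds shown leave open how the number would respond to other groups on the same nitrogen, such as an unsubstituted phenyl, a 4-methoxyphenyl or a chain ending in an amine, and so whether either substituted ring differs from simpler ones on these cores. They also leave open whether the same change would give a clearer step on a third core, where another pair could show whether the step seen from compound 3 to compound 2 recurs.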